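A few compounds are considered here, and "the series" means these few. Any claim that something is new, unique, unknown or untested is made for them only; others in the source may bear on it.

Compound 1, `C#CCOc1ccc(/C=C/C(=O)c2ccc(CC=C(C)C)cc2)cc1OC`: > 50000 nM
Compound 2, `C=CCc1cc(C(C)=O)ccc1OCC=C(C)C`: 16300 nM
Compound 3, `C#CCOc1ccc(C(CC(=O)c2cccc(Br)c2)CC(=O)c2cccc(Br)c2)cc1OC`: > 50000 nM

In a functional assay on CCRF-CEM cells (Homo sapiens) for cytotoxicity, with a stated time of 72 h (a lower number here means a stronger inhibitor, a higher number a weaker inhibitor), compound 1 gives > 50000 nM, which is a limit of the assay and not a number. Compound 3 also returns only a limit, > 50000 nM. Compound 2 alone yields a number, 16300 nM. For the measured compounds named here, compound 1 therefore stands at the limit of > 50000 nM in this assay, at which 2 of the 3 values shown sit, and no measured step connects it to any other compound here.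

The next compound, compound 4, `C#CCOc1ccc(/C=C/C(=O)c2ccc(C)cc2)cc1OC`, differs from compound 1 in one place: hydrogen in place of 2-methylprop-1-en-1-yl on a saturated chain carbon bound to an aromatic carbon. Because compound 1 sits at the limit of > 50000 nM in this assay, at which 2 of the 3 values shown sit, the step to compound 4 in this assay cannot be read from any shown pair, and no expectation is made of a change beyond the scatter in either direction. Compound 4 is therefore expected to stay at or near the limit, at an estimated 50000 nM with a range of 15000 nM to 150000 nM, a step from compound 1 of a number no higher from compound 1 to compound 4 (the limit leaves the size open) that is expected to be within the scatter.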

Compound 4, half-maximal inhibitory concentration: > 50000 nM
Compound 4: only a limit was reported; the forecaster's own chance of this, stated with the estimate: 70%; the middle value lies on the limit itself.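

In this assay compound 4 gives > 50000 nM, which is a limit of the assay and not a number. For the compounds shown here, compound 1 also stands at a limit, so no step from compound 1 to compound 4 can be read. The compounds shown leave open whether 3-methylbut-2-en-1-yl to methyl changes cytotoxicity at all.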